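Swapping the urea aryl group on a dichlorothienopyrimidine core

The source may report more compounds than this note shows. Statements on the series, on what has been measured and on what is new or still open speak of the compounds shown alone.

Of the compounds shown here, two sharing one core have been measured so far. Compound 1 `CCN(CC)CCCNc1nc(-c2ccc(NC(=O)Nc3ccc(Cl)cc3Cl)cc2)nc2c(Cl)c(Cl)sc12` gives 1170 nM in a functional assay on NCI-H460 cells (Homo sapiens) for cytotoxicity, read by MTT assay, with a stated time of 72 h; on this read-out higher numbers stand for weaker inhibition and lower numbers for stronger inhibition. Compound 2 `CCN(CC)CCNc1nc(-c2ccc(NC(=O)Nc3ccc(F)cc3)cc2)nc2c(Cl)c(Cl)sc12` gives 500 nM in this assay, the lower of the two numbers, and its gap to compound 1 is beyond the usual scatter. Compound 2 and compound 1 differ in two places at once, so neither change can be read on its own.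

Compound 3 `CCN(CC)CCNc1nc(-c2ccc(NC(=O)Nc3ccc(Cl)cc3Cl)cc2)nc2c(Cl)c(Cl)sc12` carries the change 2,4-dichlorophenyl in place of 4-fluorophenyl on an amide-type nitrogen relative to compound 2, while keeping the shorter chain of compound 2. For the measured compounds named here, no measured pair shows this change alone. Since compound 1 carries the same 2,4-dichlorophenyl and gives 1170 nM, a modest weakening is expected, though it could also be none beyond the scatter. For compound 3 the expected step from compound 2 is a 1.6-fold higher number from compound 2 to compound 3 (0.20 log units; within the scatter). Compound 3 is therefore estimated at 800 nM, with a range from 350 nM to 1800 nM.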

Compound 3, half-maximal inhibitory concentration: 1300 nM
Estimate against measurement, compound 3: 1.6-fold (0.21 log units) below, within the range that was stated.
By their numbers in this assay, from the lowest: compound 2; then compounds 1 and 3 (each within the scatter of the next).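

Compound 3 pulls apart the two changes that were tangled between compound 1 and compound 2. In this assay, with the shorter chain held fixed, 2,4-dichlorophenyl in place of 4-fluorophenyl on the amide-type nitrogen gives a 2.6-fold higher number from compound 2 to compound 3 (0.41 log units; beyond the scatter) and so shows that this aryl group matters on its own, while with 2,4-dichlorophenyl held fixed, diethylamino in place of (diethylamino)methyl gives a 1.1-fold higher number from compound 1 to compound 3 (0.05 log units; within the scatter) and so leaves the chain length without a readable effect. No measurement shown explains why the aryl swap shifts the number.

Going by these compounds, whether the chain change would also stay within the scatter with 4-fluorophenyl on the urea remains open. So does how 4-chlorophenyl or 4-methoxyphenyl on that nitrogen, or a morpholine in place of the diethylamino group, would read.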